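A few compounds are considered here, and "the series" means these few. Any claim that something is new, unique, unknown or untested is made for them only; others in the source may bear on it.

In a functional assay on GBM1 cells (Homo sapiens) for antiproliferative activity, read by WST assay, with a stated time of 72 h (on this read-out higher numbers stand for weaker inhibition and lower numbers for stronger inhibition), compound 1 `O=C(Nc1cccc(Cl)c1)Nc1cc2ncncc2cc1OCc1ccccc1Cl` gives 2600 nM and compound 2 `O=C(Nc1ccc(Cl)c(Cl)c1)Nc1cc2ncncc2cc1OCc1ccccc1F` gives 4100 nM. These two values lie within the usual scatter of each other, so compound 1 stands level with compound 2. Compound 3 `O=C(Nc1cccc(F)c1)Nc1cc2ncncc2cc1OCc1ccccc1Cl` keeps the rest of compound 1 and has fluoro in place of chloro on an aromatic carbon, turning 3-chlorophenyl into 3-fluorophenyl (fluoro in place of chloro on an aromatic carbon). Going by the values given here, no measured pair shows this change on its own. In this assay, the expected step of a 1.2-fold higher number from compound 1 to compound 3 (0.06 log units; within the scatter) is small, slightly toward weaker inhibition and probably not beyond the scatter. For compound 3 the estimated value is 3000 nM, within a range of 1300 nM to 7000 nM.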

Compound 3, half-maximal inhibitory concentration: 4000 nM
Compound 3: middle estimate off by 1.3-fold (0.12 log units), on the low side; measured number inside the range.
By their numbers in this assay, from the lowest: compounds 1, 3 and 2 (each within the scatter of the next).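

In this assay, going by these compounds alone, the step of a 1.5-fold higher number from compound 1 to compound 3 (0.19 log units; within the scatter) is the first direct comparison at this position, and it lies within the scatter. Exchanging chloro for fluoro on this aromatic carbon, meta to a large group, therefore gives no clear change in the read-out. Nothing available here explains why the two compounds read alike. The compounds shown leave open whether a different group in this place, such as a methoxy, an amine or a carboxylic acid, would move the number beyond the scatter. They also leave open what plain hydrogen in this place would give.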